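The compounds below may be only part of what the source reports. "The series", "measured", "known", "first", "only" and "open" are said of these compounds alone.

Working notes on the series. Compound 1 `COc1cc2cc(C#N)ccc2c(OC)c1Oc1cc(NC(C)(C)C)nc(Nc2ccc(C#N)cc2)n1`, compound 2 `CCCC(C)Nc1cc(Oc2c(OC)cc3cc(C#N)ccc3c2OC)nc(Nc2ccc(C#N)cc2)n1` and compound 3 `CCCCCC(C)Nc1cc(Oc2c(OC)cc3cc(C#N)ccc3c2OC)nc(Nc2ccc(C#N)cc2)n1` share one core and differ only in the group on a nitrogen on an aromatic ring. In an ADME assay on MT4 cells (Homo sapiens) for cytotoxicity, read by MTT assay, with a stated time of 5 days (on this read-out higher numbers stand for lower toxicity in this test and lower numbers for higher toxicity in this test), compound 1 gives > 125000 nM, which is a limit of the assay and not a number. In this assay compound 2 gives > 125000 nM, again a limit. In this assay compound 3 gives > 125000 nM, also a limit. Compound 3 therefore stands only at a limit, as do the two other values, a point summed up by the limit of > 125000 nM in this assay, at which 3 of the 3 values shown sit. The steps a step that the two limits leave unreadable from compound 1 to compound 2, a step that the two limits leave unreadable from compound 1 to compound 3 and a step that the two limits leave unreadable from compound 2 to compound 3 are each left unreadable by the two limits, so no size can be attached to any of them. Compound 4 `COc1cc2cc(C#N)ccc2c(OC)c1Oc1cc(NC2CCOC2)nc(Nc2ccc(C#N)cc2)n1` carries the change (oxolan-3-yl in place of 1-methylhexyl on a nitrogen on an aromatic ring). Among the measured compounds shown here, no measured step bears on this change with a readable size: every step recorded runs between limits and gives no direction. The expectation for compound 4 in this assay thus rests on three compounds sitting at the limit. The step of a number no higher from compound 3 to compound 4 (the limit leaves the size open) is expected to be none beyond the scatter, with compound 4 expected to come back at the limit again. The estimate for compound 4 is 125000 nM, with a range from 60000 nM to 250000 nM.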

Compound 4, half-maximal cytotoxic concentration: > 125000 nM
Compound 4 ended at the assay's limit (the forecaster's own chance of this, stated with the estimate: 85%); the middle value sits exactly at the limit.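

The steps from compound 1, compound 2 and compound 3 to compound 4 in this assay cannot be read: each runs between two limits. The compounds shown leave open where the half-maximal cytotoxic concentration of any of them lies, and whether the group on the nitrogen changes it at all: the limit of > 125000 nM in this assay, at which 4 of the 4 values shown sit.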